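This account rests on a few compounds, and the source may have more. Where it says the series, first, only, none or still open, it means among the compounds named here.

Among the measured compounds shown here, compound 2 `COc1cccc(OC)c1OCCNCCOc1ccccc1OCc1ccccc1Cl` gives 7.52 in a functional assay on spleen for antagonist activity at Alpha-1B adrenergic receptor (Rattus norvegicus) (on this read-out lower numbers stand for lower potency and higher numbers for higher potency (the scale is a negative logarithm)), the lower of the two numbers in hand; compound 1 `COc1cccc(OC)c1OCCNCCOc1ccccc1OCc1ccccc1` gives 8.3, and the only measured step, a number 0.78 log units lower from compound 1 to compound 2 (beyond the scatter), shows what a chlorine added on an aromatic carbon did. Compound 3 `COc1cccc(OC)c1OCCNCCOc1ccccc1OCc1cccc(Cl)c1` differs from compound 2 by 3-chlorophenyl in place of 2-chlorophenyl on a saturated chain carbon bound to an oxygen on an aromatic ring. For the measured compounds named here, no measured step shows the effect of moving a chlorine, so the direction is uncertain, and a step near the scatter is expected, with some chance of partial recovery toward compound 1. Compound 3 is therefore estimated at 7.7, between 7.1 and 8.3, a step of a number 0.18 log units higher from compound 2 to compound 3 (within the scatter).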

Compound 3, negative logarithm of the antagonist equilibrium constant: 7.93
Compound 3: the middle estimate sits 0.23 log units below what was measured, and the stated range covers the measured number.
By their numbers in this assay, from the lowest: compound 2; then compound 3; then compound 1.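

In this assay, the same atoms joined differently give a real change: with 3-chlorophenyl in place of 2-chlorophenyl there is a number 0.41 log units higher from compound 2 to compound 3 (beyond the scatter) in this series. The cost of adding a chlorine therefore depends on where it stands, although 3-chlorophenyl still leaves a number 0.37 log units lower from compound 1 to compound 3 (beyond the scatter) as a loss that is beyond the scatter. Nothing available explains the difference between these two chlorophenyl compounds. From the compounds shown here alone, it remains open whether a fluorine or a methyl in place of the chlorine would follow the same order. Going by these compounds, it also remains open whether any such group could match compound 1.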